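The compounds below may be only part of what the source reports. "The series", "measured", "known", "first", "only" and "open" are said of these compounds alone.

In a physicochemical assay for metabolic stability, in the presence of a further agent that is not named here (on this read-out lower numbers stand for a shorter-lived compound and higher numbers for a longer-lived compound), compound 1 `Cc1cn([C@H]2C[C@H](SSc3ccc([N+](=O)[O-])cc3)[C@@H](CO)O2)c(=O)[nH]c1=O`, with 4-nitrophenyl on a sulfur, gives < 0.167 h, which is a limit and not a number. Compound 2 `C=CCSS[C@H]1C[C@H](n2cc(C)c(=O)[nH]c2=O)O[C@@H]1CO`, with allyl at that sulfur, gives < 8 h, also a limit. Compound 3 `CCCCSS[C@H]1C[C@H](n2cc(C)c(=O)[nH]c2=O)O[C@@H]1CO`, with butyl there, gives < 8 h, again a limit. Compound 2 thus stands at the limit of < 8 h in this assay, at which 2 of the 3 values shown sit, and nothing tighter is known of it.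

Compound 4 `Cc1cn([C@H]2C[C@H](SSCCO)[C@@H](CO)O2)c(=O)[nH]c1=O` departs from compound 2 by hydroxymethyl in place of vinyl on a saturated chain carbon bound to a sulfur, which also reads as allyl to 2-hydroxyethyl. Going by the values given here, three measured steps bear on this change. Among the compounds with values here, the first two are a step that the two limits leave unreadable from compound 1 to compound 2 and a step that the two limits leave unreadable from compound 1 to compound 3. The closest is a step that the two limits leave unreadable from compound 2 to compound 3, since it changes the same place. None of the three gives a size, so no direction can be carried over to the new group.

The expectation therefore rests on compound 2, whose < 8 h is a limit. The expected change is a step that the limit leaves unreadable from compound 2 to compound 4, with no shift beyond the scatter predicted. For compound 4 the estimated half-life is 3 h, with an expected range of 0.7 h to 8 h.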

Compound 4, half-life: < 8 h
Compound 4: only a limit was reported; the forecaster's own chance of this, stated with the estimate: 50%; the middle value is on the limit's open side.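

In this assay compound 4 gives < 8 h, which is a limit. Its steps from compound 1, compound 2 and compound 3 cannot be read. The compounds shown leave open the actual half-life of each of the four compounds in this assay, and whether the group on the sulfur shifts it at all.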